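Swapping the side chain on a long-lived sulfonamide

The source may hold more compounds than are shown below. What is called first, only, known or untested is meant among the compounds shown, and "the series" means these compounds.

Measured so far:
- compound 1, `CC(C)CCn1nc(CCC(F)(F)F)c(O)c(C2=NS(=O)(=O)c3cc(NS(C)(=O)=O)ccc3N2)c1=O`: 0.517 h
- compound 2, `COC(C)(C)CCn1nc(-c2cccs2)c(O)c(C2=NS(=O)(=O)c3cc(NS(C)(=O)=O)ccc3N2)c1=O`: > 1 h

Of the compounds shown here, two sharing one core have been tested in an in vitro ADME assay on microsomes from liver (Homo sapiens) for metabolic stability, tested at 5 uM; on this read-out lower numbers stand for a shorter-lived compound and higher numbers for a longer-lived compound. Compound 1 gives 0.517 h, a plain number. Compound 2 reaches only > 1 h, which is a limit of the assay rather than a number. As far as these compounds go, compound 2 therefore stands at the limit of > 1 h in this assay, at which 1 of the 2 values shown sits, so how far its true half-life lies beyond that point is unknown.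

Compound 3, `CS(=O)(=O)Nc1ccc2c(c1)S(=O)(=O)N=C(c1c(O)c(-c3cccs3)nn(Cc3ccccn3)c1=O)N2`, has not yet been measured in this assay. It differs from compound 2 in one spot: pyridin-2-yl in place of 2-methoxy-2-methylpropyl on a saturated chain carbon bound to an aromatic nitrogen. The shared core, with its hydroxyl, thiophene and the fused sulfonamide ring, is untouched.

Going by the values given here, no measured pair differs in a single place, so no step size can be read from the data. With compound 2 known only as a limit, the change is expected to leave the half-life in the same region or shift it modestly downward, a step of a number no higher from compound 2 to compound 3 (the limit leaves the size open). Compound 3 is accordingly estimated at 1 h, with a range from 0.4 h to 2.5 h.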

Compound 3, half-life: > 1 h
Compound 3: a limit, no number (the forecaster's own chance of this, stated with the estimate: 45%); the middle value sits exactly at the limit.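

Going by these compounds alone, compound 2 and compound 3 both sit at a limit of the assay rather than at a number, so no step between them can be read in this assay. As far as these compounds go, how far the true half-life of either compound lies past that limit stays open, and so does whether pyridin-2-yl in place of 2-methoxy-2-methylpropyl changes it at all.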